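A few compounds are considered here, and "the series" means these few. Any claim that something is new, unique, unknown or untested is made for them only; others in the source may bear on it.

Measured in a functional assay on HL-60 cells (Homo sapiens) for antiproliferative activity, read by MTT assay, with a stated time of 72 h; on this read-out higher numbers stand for weaker inhibition and lower numbers for stronger inhibition:

compound 1, `CCC(=O)N(C)c1ccc2[nH]c(-c3n[nH]c4ccccc34)cc2n1`: 6130 nM
compound 2, `CN(c1ccc2[nH]c(-c3n[nH]c4ccccc34)cc2n1)S(=O)(=O)c1ccccc1`: 3700 nM
compound 3, `Cc1ccc(S(=O)(=O)N(C)c2ccc3[nH]c(-c4n[nH]c5ccccc45)cc3n2)cc1`: 3030 nM

Compound 1 gives the highest number of the three in this assay, although its gap to compound 2 is within the scatter and only its gap to compound 3 is beyond it. Compound 4, `CN(c1ccc2[nH]c(-c3n[nH]c4ccccc34)cc2n1)S(=O)(=O)c1ccc(Br)cc1`, is not yet measured. It differs from compound 1 in one place: (4-bromophenyl)sulfonyl in place of propanoyl on a nitrogen on an aromatic ring. For the measured compounds named here, two measured steps bear on this change, since both also swap the propanoyl for a sulfonyl group on the same nitrogen: a 1.7-fold lower number from compound 1 to compound 2 (0.22 log units; within the scatter) and a 2.0-fold lower number from compound 1 to compound 3 (0.31 log units; beyond the scatter). Adding a methyl to the ring of the sulfonyl changed little, as a 1.2-fold lower number from compound 2 to compound 3 (0.09 log units; within the scatter) shows. A (4-bromophenyl)sulfonyl is expected to behave like these two, so a small move toward a lower number in this assay, about a 1.9-fold lower number from compound 1 to compound 4 (0.28 log units; within the scatter), is estimated for compound 4. Compound 4 is therefore expected to give about 3200 nM in this assay, with a likely range from 1600 nM to 6400 nM.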

Compound 4, half-maximal inhibitory concentration: 6240 nM
Estimate against measurement, compound 4: 2.0-fold (0.29 log units) below; the measured number falls inside the stated range.
By their numbers in this assay, from the lowest: compounds 3, 2, 1 and 4 (each within the scatter of the next, the first and the last beyond it).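

The step to a (4-bromophenyl)sulfonyl on this nitrogen is a 1.0-fold higher number from compound 1 to compound 4 (0.01 log units; within the scatter) in this assay, so putting a sulfonyl in place of propanoyl does not by itself set a compound apart from compound 1. What sits on the ring of the sulfonyl can make a modest difference: bromo in place of methyl gives a 2.1-fold higher number from compound 3 to compound 4 (0.31 log units; beyond the scatter), while bromo in place of hydrogen gives a 1.7-fold higher number from compound 2 to compound 4 (0.23 log units; within the scatter). Nothing measured on these compounds accounts for this difference between bromo and methyl.

The compounds shown leave open what other groups on that ring would do, such as a fluoro, a methoxy or a carboxylic acid. On these data alone, the methyl on this nitrogen also stays the same in all four compounds, so the effect of a hydrogen or an ethyl there remains unknown.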